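One Group Exchanged: From Compound 1 to Compound 4

A few compounds are considered here, and "the series" means these few. Any claim that something is new, unique, unknown or untested is made for them only; others in the source may bear on it.

Measured so far:
compound 1 `FC(F)(F)c1ccc2[nH]c(-c3ccc(-c4nnc[nH]4)cc3)nc2c1`: 3080 nM
compound 2 `O=[N+]([O-])c1ccc2[nH]c(-c3ccc(Cl)c(Br)c3)nc2c1`: > 31600 nM (a limit)
compound 3 `O=[N+]([O-])c1ccc2[nH]c(-c3ccc(Cl)cc3Br)nc2c1`: 1760 nM

All three were tested in a functional assay for antagonist activity at Neuropeptides B/W receptor type 1 (Homo sapiens), read by cAMP accumulation; on this read-out lower numbers stand for stronger inhibition and higher numbers for weaker inhibition. Compound 1 gives 3080 nM, and compound 3 gives 1760 nM; these two numbers lie within the usual scatter of each other, so neither can be called stronger. Compound 2 reaches only the limit of this assay, (the limit of > 31600 nM in this assay, at which 1 of the 3 values shown sits), and yields no number.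

Compound 4 `NCc1ccc(-c2ccc(-c3nc4cc(C(F)(F)F)ccc4[nH]3)cc2)cc1` differs from compound 1 in one place: 4-(aminomethyl)phenyl in place of 4H-1,2,4-triazol-3-yl on an aromatic carbon. Within the data shown here, no measured pair shows what such an exchange does. The expected step from compound 1 to compound 4 is a 1.2-fold lower number from compound 1 to compound 4 (0.09 log units; within the scatter), which is not beyond the scatter. Compound 4 is therefore estimated at 2500 nM, with a range from 500 nM to 12000 nM.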

Compound 4, half-maximal inhibitory concentration: 720 nM
The estimate for compound 4 lay 3.5-fold (0.54 log units) above the measured number; the range from low to high includes it.
By their numbers in this assay, from the lowest: compound 4; then compounds 3 and 1 (each within the scatter of the next). At a limit, above all of these: compound 2.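

Among these compounds, the exchange of 4H-1,2,4-triazol-3-yl for 4-(aminomethyl)phenyl gives a 4.3-fold lower number from compound 1 to compound 4 (0.63 log units; beyond the scatter) and is the first single change in this set that can be read. This aromatic carbon therefore accepts a larger group, and in this pair 4H-1,2,4-triazol-3-yl is not needed for inhibition. Nothing measured here explains the step.

Whether the ring or its aminomethyl group accounts for the lower number stays open. A plain phenyl, or a phenyl carrying a carboxylic acid or a longer amine chain, would help separate the two.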